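Swapping trifluoromethoxy for (trifluoromethyl)sulfanyl at a solubility limit

The source may hold more compounds than are shown below. What is called first, only, known or untested is meant among the compounds shown, and "the series" means these compounds.

Of the compounds shown here, three on a shared core have been tested in a physicochemical assay for solubility, using the shake flask method, in simulated intestinal fluid, measured as kinetic solubility, with a stated time of 2 h, at 25 degrees C, at pH 6.5 (on this read-out higher numbers stand for higher solubility and lower numbers for lower solubility), and they differ in one group on an aromatic carbon. Compound 1 (`Cc1noc(-c2nc(C)c3c(c2N)C(=O)N(Cc2ccc(-n4cccn4)cc2)C3=O)n1`) carries 1H-pyrazol-1-yl, compound 2 (`Cc1noc(-c2nc(C)c3c(c2N)C(=O)N(Cc2ccc(Cl)cc2)C3=O)n1`) carries chloro and compound 3 (`Cc1noc(-c2nc(C)c3c(c2N)C(=O)N(Cc2ccc(OC(F)(F)F)cc2)C3=O)n1`) carries trifluoromethoxy. Compound 1 gives < 5000 nM, which is a limit and not a number. Compound 2 gives < 5000 nM, also a limit. Compound 3, the starting point here, gives < 5000 nM, likewise a limit. The evidence so far is the limit of < 5000 nM in this assay, at which 3 of the 3 values shown sit.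

Compound 4 (`Cc1noc(-c2nc(C)c3c(c2N)C(=O)N(Cc2ccc(SC(F)(F)F)cc2)C3=O)n1`) has (trifluoromethyl)sulfanyl in place of trifluoromethoxy on an aromatic carbon. The measured steps that bear on this change are a step that the two limits leave unreadable from compound 2 to compound 3 and a step that the two limits leave unreadable from compound 1 to compound 3, with a step that the two limits leave unreadable from compound 1 to compound 2 as a further comparison. None of them offers a size or a direction to carry over, so no clear change is expected in this assay. The expected outcome is a step that the limit leaves unreadable from compound 3 to compound 4. Compound 4 is estimated at 2000 nM, with an expected range of 500 nM to 5000 nM.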

Compound 4, solubility: < 5000 nM
Compound 4 was reported as a limit; the forecaster's own chance of this, stated with the estimate: 90%; the middle value does not contradict the limit.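

In this assay compound 4 gives < 5000 nM, which is a limit and not a number. Its steps from compound 1, compound 2 and compound 3 cannot be read. The compounds shown leave open whether these four groups differ at all in solubility: the limit of < 5000 nM in this assay, at which 4 of the 4 values shown sit.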